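Swapping cyclopropyl for ethyl on the sulfonamide nitrogen

The source may hold more compounds than are shown below. What is called first, only, known or untested is meant among the compounds shown, and "the series" means these compounds.

In a physicochemical assay for solubility, in phosphate buffer, measured as kinetic solubility, with a stated time of 24 h, at pH 7.4 (a lower number here means a less soluble compound, a higher number a more soluble compound), compound 3 `CC(=O)N1CCN(c2ccc(CN(C3CC3)S(=O)(=O)Cc3ccccc3)cc2)CC1` gives 71000 nM. Compound 2 `CCCN(Cc1ccc(N2CCN(C(C)=O)CC2)cc1)S(=O)(=O)Cc1ccccc1` gives 40000 nM, within the scatter of compound 3. Compound 1 `CC(=O)N1CCN(c2ccc(CN(CC(C)C)S(=O)(=O)Cc3ccccc3)cc2)CC1` is reported only as a limit, <= 1000 nM.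

Compound 4 `CCN(Cc1ccc(N2CCN(C(C)=O)CC2)cc1)S(=O)(=O)Cc1ccccc1` differs from compound 3 by ethyl in place of cyclopropyl on a sulfonamide nitrogen. The closest measured change is a 1.8-fold higher number from compound 2 to compound 3 (0.25 log units; within the scatter), with cyclopropyl in place of propyl at that same nitrogen, and it stays within the scatter. Two large steps, an at least 40-fold higher number from compound 1 to compound 2 (1.60 log units; beyond the scatter) and an at least 71-fold higher number from compound 1 to compound 3 (1.85 log units; beyond the scatter), start from a limit and leave an isobutyl group, which plays no part in the present change, so they bear on it only loosely. Ethyl is a shorter chain than the propyl of compound 2, and no step beyond the scatter is expected in this assay. The expected step, slightly downward if anything, is a 1.3-fold lower number from compound 3 to compound 4 (0.11 log units; within the scatter). Compound 4 is estimated at 55000 nM, with an expected range of 25000 nM to 110000 nM.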

Compound 4, solubility: 31000 nM
Beside the measured number, compound 4's estimate is 1.8-fold (0.25 log units) above it, and the stated range covers the measured number.
By their numbers in this assay, from the lowest: compounds 4, 2 and 3 (each within the scatter of the next, the first and the last beyond it). At a limit, below all of these: compound 1.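

In this assay this nitrogen now shows a step beyond the scatter among its small groups (a 2.3-fold lower number from compound 3 to compound 4 (0.36 log units; beyond the scatter)), a modest one, whereas the change from propyl to cyclopropyl had stayed within it. The two straight chains do not separate (a 1.3-fold lower number from compound 2 to compound 4 (0.11 log units; within the scatter)), which stays within the scatter, so cyclopropyl parts clearly from ethyl but not from propyl. From the compounds shown here alone, the step from the isobutyl compound is large (an at least 31-fold higher number from compound 1 to compound 4 (1.49 log units; beyond the scatter)), but compound 1 stands only as a limit, so its true size stays unknown: (the limit of <= 1000 nM in this assay, at which 1 of the 4 values shown sits).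

The compounds shown leave open where between the propyl and isobutyl groups the large step sets in, for instance with a straight butyl chain. They also leave open how a cyclobutyl ring or a chain carrying an amine would stand at this nitrogen.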